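Compound 1 Meets a Bulkier Alkyl on the Aromatic Ring

The source may report more compounds than this note shows. Statements on the series, on what has been measured and on what is new or still open speak of the compounds shown alone.

Within the data shown here, compound 1 `O=[N+]([O-])c1ccc2c(c1)S(=O)(=O)N=C2Nc1ccccc1` holds the only definite number here: in an assay on isolated protein for inhibition of Polyunsaturated fatty acid 5-lipoxygenase (Homo sapiens), read by fluorescence and spectrophotometry, with a stated time of 10 min (on this read-out lower numbers stand for stronger inhibition and higher numbers for weaker inhibition), compound 1 gives 8600 nM. Compound 2 `Cc1ccccc1NC1=NS(=O)(=O)c2cc([N+](=O)[O-])ccc21` reaches only a limit of the assay, giving > 50000 nM in this assay. Among the measured compounds shown here, the one measured step, an at least 5.8-fold higher number from compound 1 to compound 2 (0.76 log units; beyond the scatter), weakens inhibition, and its size rests on (the limit of > 50000 nM in this assay, at which 1 of the 2 values shown sits). Compound 3 `CC(C)(C)c1cccc(NC2=NS(=O)(=O)c3cc([N+](=O)[O-])ccc32)c1` differs from compound 1 by tert-butyl in place of hydrogen on an aromatic carbon. This change resembles the methyl step in kind and is larger in bulk, so weaker inhibition is expected, a 4.7-fold higher number from compound 1 to compound 3 (0.67 log units; beyond the scatter). Compound 3 is therefore estimated at 40000 nM, within a range from 12000 nM to 150000 nM.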

Compound 3, half-maximal inhibitory concentration: 60 nM
Compound 3: middle estimate off by 670-fold (2.82 log units), on the high side, and the stated range ends above it.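

Tert-butyl on an aromatic carbon, meta to a large group, gives a 140-fold lower number from compound 1 to compound 3 (2.16 log units; beyond the scatter) in this assay, so this position accepts a large alkyl group and inhibition strengthens sharply. Adding an alkyl group to this ring therefore does not weaken inhibition as such, for the methyl step, an at least 5.8-fold higher number from compound 1 to compound 2 (0.76 log units; beyond the scatter), runs the opposite way. The size of that methyl step stays open-ended: the limit of > 50000 nM in this assay, at which 1 of the 3 values shown sits.

The compounds shown leave open whether methyl at the tert-butyl position would also strengthen inhibition. They also leave open how isopropyl, an amine or a carboxylic acid would behave there.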